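Positional shift of chlorine on the benzyl ether

A few compounds are considered here, and "the series" means these few. Any claim that something is new, unique, unknown or untested is made for them only; others in the source may bear on it.

Compound 2, `CCC1(Cc2ccccc2)OS(=O)(=O)C=C1OCc1ccccc1Cl`, is the point of departure. In an ADME assay on HEL cells (Homo sapiens) for cytotoxicity, with a stated time of 3 days (on this read-out higher numbers stand for lower toxicity in this test and lower numbers for higher toxicity in this test), compound 2 gives >= 20000 nM, which is a limit of the test and not a number. Compound 1, `CCC1(Cc2ccccc2)OS(=O)(=O)C=C1OCC#N`, gives in this assay > 400000 nM, again a limit. Compound 3, `CC1(C(c2ccccc2)c2ccccc2)OS(=O)(=O)C=C1OCc1ccccc1`, gives in this assay >= 400000 nM, also a limit. Every value shown is thus a limit (the limit of > 400000 nM in this assay, at which 1 of the 3 values shown sits, (the limit of >= 20000 nM in this assay, at which 1 of the 3 values shown sits), (the limit of >= 400000 nM in this assay, at which 1 of the 3 values shown sits)), so compound 2 cannot be placed above or below the other two on this read-out. The only measured step that joins two of these compounds, a step that the two limits leave unreadable from compound 1 to compound 2, is likewise unreadable in size.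

Compound 4, `CCC1(Cc2ccccc2)OS(=O)(=O)C=C1OCc1cccc(Cl)c1`, differs from compound 2 by 3-chlorophenyl in place of 2-chlorophenyl on a saturated chain carbon bound to an oxygen on an unsaturated carbon. Going by the values given here, no measured step in this set moves a chlorine along the ring, so nothing here gives the size of this change directly. With all three values resting at limits and no readable step in any direction, the step that the limit leaves unreadable from compound 2 to compound 4 is expected to be none beyond the scatter, and compound 4 is expected to come out at a limit as well. For compound 4 the estimate in this assay is 100000 nM, with a range from 20000 nM to 400000 nM.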

Compound 4, minimum cytotoxic concentration: >= 20000 nM
Compound 4: no number, only a limit (the forecaster's own chance of this, stated with the estimate: 85%); the middle value is on the limit's open side.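

In this assay compound 4 gives >= 20000 nM, a limit of the test and not a number. Neither the step from compound 2 to compound 4 nor the step from compound 1 to compound 4 can be read. The compounds shown leave open whether 3-chlorophenyl in place of 2-chlorophenyl shifts this read-out at all.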